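Exchanging an Aminophenyl Amide for a Methylpyridyl Amide

This account rests on a few compounds, and the source may have more. Where it says the series, first, only, none or still open, it means among the compounds named here.

Measured compounds:
compound 1 `O=C(Nc1nnc(-c2ccc3c(c2)OCCO3)s1)c1ccccc1` — in a functional assay on HepG2 cells (Homo sapiens) for antiproliferative activity, read by MTT assay, with a stated time of 48 h (a higher number here means that more compound is needed for the effect, a lower number that less compound is needed), compound 1 gives 34.8 ug/mL
compound 2 `Nc1ccc(C(=O)Nc2nnc(-c3ccc4c(c3)OCCO4)s2)cc1` — compound 2 gives > 100 ug/mL, which is a limit of the assay and not a number
compound 3 `O=C(Nc1nnc(-c2ccc3c(c2)OCCO3)s1)c1ccncc1` — compound 3 gives > 100 ug/mL, likewise a limit of the assay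

Compound 2 therefore stands at the limit of > 100 ug/mL in this assay, at which 2 of the 3 values shown sit, with no number of its own. Compound 4 `Cc1ccc(C(=O)Nc2nnc(-c3ccc4c(c3)OCCO4)s2)cn1` differs from compound 2 by 6-methylpyridin-3-yl in place of 4-aminophenyl on a carbonyl carbon. Among the measured compounds shown here, two measured steps bear on this change. The step of an at least 2.8-fold higher number from compound 1 to compound 3 (0.45 log units; beyond the scatter) puts a pyridyl ring in place of a carbon-only ring on the carbonyl carbon and weakened the effect by at least a modest amount. The step that the two limits leave unreadable from compound 2 to compound 3 concerns the same carbonyl position but runs between two limits and cannot be read. For the measured compounds named here, since compound 2 starts at the limit and the only readable pyridyl step points toward weaker activity, a step of a number no higher from compound 2 to compound 4 (the limit leaves the size open) is expected, with compound 4 most likely remaining at the limit. Compound 4 is estimated at 100 ug/mL, in the range 40 ug/mL to 250 ug/mL.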

Compound 4, half-maximal effective concentration: > 100 ug/mL
Compound 4 ended at the assay's limit (the forecaster's own chance of this, stated with the estimate: 65%); the middle value sits exactly at the limit.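

On the carbonyl carbon in this assay, 6-methylpyridin-3-yl in place of phenyl gives an at least 2.8-fold higher number from compound 1 to compound 4 (0.45 log units; beyond the scatter), so a second pyridyl ring, this one carrying a methyl group, also falls short of the phenyl of compound 1. Compound 4 also shows that giving up the hydrogen-bond donor counted on the 4-aminophenyl of compound 2 brings no measurable value in this series, since its reading is again a limit of the assay and not a number. The steps from compound 2 and compound 3 to compound 4 join two limits and cannot be read, and the position now stands mostly at the ceiling: the limit of > 100 ug/mL in this assay, at which 3 of the 4 values shown sit.

Any order among compound 2, compound 3 and compound 4 remains open. Also open, as far as these compounds go, is whether a chlorine or a methoxy group on the phenyl ring of compound 1 would give a readable number.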